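Trifluoromethoxy in place of hydroxy on the arylpiperazine of compound 3

The source may hold more compounds than are shown below. What is called first, only, known or untested is meant among the compounds shown, and "the series" means these compounds.

Measured compounds:
Compound 1, `COc1ccccc1N1CCN(CCCSc2ccccc2C(=O)N(C)C)CC1` — 2 nM in a functional assay for antagonist activity at Alpha-1A adrenergic receptor (Oryctolagus cuniculus); a higher number here means weaker binding, a lower number tighter binding
Compound 2, `CN(C)C(=O)c1cccnc1NCCCN1CCN(c2ccccc2)CC1` — 6.31 nM in this assay
Compound 3, `CN(C)C(=O)c1cccnc1NCCCN1CCN(c2ccccc2O)CC1` — 5.01 nM in this assay

In this assay compound 3 stands second highest of the three numbers. Its nearest neighbour is compound 2, whose value sits within the scatter of it, so no order between compound 2 and compound 3 can be claimed; the furthest is compound 1, whose lower number lies beyond the scatter. Among the measured compounds shown here, the one step that runs between compounds of the shared core is a 1.3-fold lower number from compound 2 to compound 3 (0.10 log units; within the scatter), and it stays within the scatter.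

Compound 4, `CN(C)C(=O)c1cccnc1NCCCN1CCN(c2ccccc2OC(F)(F)F)CC1`, has not yet been measured in this assay. It differs from compound 3 by trifluoromethyl in place of hydrogen on an oxygen on an aromatic ring. For the measured compounds named here, no measured pair shows an alkyl or fluorinated group entering on that oxygen; compound 1 carries a methoxy group but also a different core, so its value cannot be read as a step. Going by the values given here, the only step that bears on the site, from compound 2 to compound 3, was within the scatter, and on that basis the expected step of a 1.0-fold lower number from compound 3 to compound 4 (0.00 log units; within the scatter) is none beyond the scatter. Compound 4 is therefore estimated at 5 nM, with a range from 1.5 nM to 16 nM.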

Compound 4, dissociation constant: 3.16 nM
Compound 4: middle estimate off by 1.6-fold (0.20 log units), on the high side, within the range that was stated.
By their numbers in this assay, from the lowest: compounds 1, 4, 3 and 2 (each within the scatter of the next, the first and the last beyond it).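

In this assay, among the compounds shown here, the measurement gives the first reading of a group entering on the oxygen of the arylpiperazine: trifluoromethyl in place of hydrogen gives a 1.6-fold lower number from compound 3 to compound 4 (0.20 log units; within the scatter), so replacing that hydrogen with four heavy atoms and removing the hydroxy group's donor does not shift the number beyond the scatter. The direct entry of trifluoromethoxy gives a 2.0-fold lower number from compound 2 to compound 4 (0.30 log units; within the scatter), so neither this group nor hydroxy at that place has yet separated from compound 2, and the site appears tolerant of both groups. Nothing measured here explains why these steps are small.

From the compounds shown here alone, what an amine, a carboxylic acid or a longer alkoxy chain would do at this place on the shared core remains open. So does the effect of methoxy on that core, since among these compounds it appears only on the core of compound 1.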